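The source may hold more compounds than are shown below. What is called first, only, known or untested is meant among the compounds shown, and "the series" means these compounds.

Measured so far:
Compound 1 `O=C(N/N=C/c1cccc(Cl)c1)c1cccnc1Nc1cccc(C(F)(F)F)c1` — 76.7%
Compound 2 `O=C(N/N=C/c1ccc(O)cc1)c1cccnc1Nc1cccc(C(F)(F)F)c1` — 70.5%

In a functional assay on the whole organism (strain Wistar) for inhibition, with Rattus norvegicus as the target, read by paw edema, with a stated time of 1 h, at a dose of 10 mg/kg by the intraperitoneal route (a lower number here means less inhibition, a higher number more inhibition at the dose given (going by the name of the read-out)), compound 1 gives 76.7% and compound 2 gives 70.5%. For the measured compounds named here, compound 2 holds the lower of the two numbers, with compound 1 as its only neighbour, but the step of a number 6.2 percentage points lower from compound 1 to compound 2 (within the scatter) lies within the scatter, so the two cannot be placed in any order.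

Compound 3 `COc1cccc(/C=N/NC(=O)c2cccnc2Nc2cccc(C(F)(F)F)c2)c1` differs from compound 2 in one place: 3-methoxyphenyl in place of 4-hydroxyphenyl on a carbon with a double bond to nitrogen. Going by the values given here, the single measured step that bears on this exchange is the one from compound 1 to compound 2, where one ring on the carbon with a double bond to nitrogen was swapped for another, a number 6.2 percentage points lower from compound 1 to compound 2 (within the scatter), and that swap stayed within the scatter. The change from 4-hydroxyphenyl to 3-methoxyphenyl is of the same kind, so a step of no more than the scatter, in either direction, is expected, a number 2.5 percentage points higher from compound 2 to compound 3 (within the scatter). Compound 3 is accordingly estimated to give 73% in this assay, with a range from 60% to 85%.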

Compound 3, a percentage reported as inhibition, in the whole organism at one dose (the size of the read-out at that dose, not a potency): 58.8%
The estimate for compound 3 lay 14.2 percentage points above the measured number; the whole stated range lies above it.
By their numbers in this assay, from the lowest: compound 3; then compounds 2 and 1 (each within the scatter of the next).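

For the compounds shown here, the ring on the carbon with a double bond to nitrogen turns out to be less freely exchangeable than the earlier pair suggested: in this assay the exchange of 4-hydroxyphenyl for 3-methoxyphenyl gives a number 11.7 percentage points lower from compound 2 to compound 3 (beyond the scatter), the first step to go beyond the scatter. The comparison with the 3-chlorophenyl compound gives a number 17.9 percentage points lower from compound 1 to compound 3 (beyond the scatter), and there only methoxy in place of chloro on an aromatic carbon changes, so the identity of the group on the ring matters even when the rest of the molecule stays the same. Nothing available bears on why the number falls with methoxy.

The step from 4-hydroxyphenyl to 3-methoxyphenyl changes both the group and where it sits on the ring, so the compounds shown cannot separate those two changes. Also open, as far as these compounds go, is whether the lower number belongs to methoxy alone or would also appear with an ethoxy group or an amine on the ring, and where a plain phenyl ring would stand against these three compounds.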